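Removing One Methoxy Group: What to Expect for Compound 4

The compounds below may be only part of what the source reports. "The series", "measured", "known", "first", "only" and "open" are said of these compounds alone.

Compound 1 `COc1cc(-c2cc(/C=C/C(=O)c3ccc(N)cc3)[nH]n2)cc(OC)c1OC` and compound 2 `COc1ccc(-c2cc(/C=C/C(=O)c3ccc(N)cc3)[nH]n2)cc1OC` share one core and differ in a single place: hydrogen in place of methoxy on an aromatic carbon. In a functional assay on MDA-MB-468 cells (Homo sapiens) for cytotoxicity, read by sulforhodamine B assay, with a stated time of 48 h, tested at 0.1 uM (on this read-out lower numbers stand for a stronger effect and higher numbers for a weaker effect at the one concentration tested), compound 1 gives 83%, and compound 2 gives 91%; the step of a number 8 percentage points higher from compound 1 to compound 2 (within the scatter) is small. Compound 3 `COc1cc(C(=O)/C=C/c2cc(-c3cc(OC)c(OC)c(OC)c3)n[nH]2)cc(OC)c1OC` has a different core; the difference between the two cores is not broken down here. In this assay compound 3 gives 84%. Compound 4 `COc1ccc(-c2cc(/C=C/C(=O)c3cc(OC)c(OC)c(OC)c3)[nH]n2)cc1OC` is not yet measured and arises from compound 3 by the same change, (hydrogen in place of methoxy on an aromatic carbon), made at a place described in the same words as before. Because the earlier step of a number 8 percentage points higher from compound 1 to compound 2 (within the scatter) stayed within the scatter, compound 4 is expected to show a similarly small step a number 6 percentage points higher from compound 3 to compound 4 (within the scatter). Compound 4 is therefore estimated at 90%, with a likely range from 78% to 100%.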

Compound 4, a percentage reported as activity, at one concentration (the size of the read-out at that concentration, not a potency): 91%
The estimate for compound 4 lay 1 percentage points below the measured number, within the range that was stated.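

In this assay, hydrogen in place of methoxy on an aromatic carbon gives a number 7 percentage points higher from compound 3 to compound 4 (within the scatter). Set beside the earlier step, the same change looks alike on the two cores: the same change on two cores in this assay, a number 8 percentage points higher (within the scatter) from compound 1 to compound 2 and a number 7 percentage points higher (within the scatter) from compound 3 to compound 4, 1 percentage points apart, within the scatter of two such steps

Among the compounds shown here, this shows only that the change leaves the read-out within the usual scatter on both cores at the one concentration tested; it does not show that the change has a real effect on either core, or that it would behave the same way on a third core.

The compounds shown leave open what a different group at this place, such as a hydroxyl group, a chlorine atom or a carboxylic acid, would do to the read-out.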